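Vero Cell Cytotoxicity of Four Related Compounds

This account rests on a few compounds, and the source may have more. Where it says the series, first, only, none or still open, it means among the compounds named here.

Compound 1, `O=C(O)c1cn(-c2ccc(F)cc2)c2nc(N3CCN(C(c4ccccc4)c4ccc(Cl)cc4)CC3)c([N+](=O)[O-])cc2c1=O`, gives 102000 nM in an ADME assay on Vero cells (Chlorocebus sabaeus) for cytotoxicity, read by MTT assay, with a stated time of 72 h; a lower number here means a stronger inhibitor, a higher number a weaker inhibitor.
Compound 2, `O=C(O)c1cn(-c2ccc(F)cc2)c2nc(N3CCN(C(=O)C4COc5ccccc5O4)CC3)c([N+](=O)[O-])cc2c1=O`, reaches only a limit of > 54300 nM in this assay.
Compound 3, `CC(C)(C)n1cc(C(=O)O)c(=O)c2cc([N+](=O)[O-])c(N3CCN(C(c4ccccc4)c4ccc(Cl)cc4)CC3)nc21`, reaches only a limit of > 108000 nM in this assay.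

All three measured compounds are weak in this assay. For the measured compounds named here, the one counted change among them is tert-butyl in place of 4-fluorophenyl on an aromatic nitrogen, and its step is an at least 1.0-fold higher number from compound 1 to compound 3 (0.02 log units; that floor lies within the scatter). That step is bounded by the limit of > 108000 nM in this assay, at which 1 of the 3 values shown sits, so its true size is not known beyond that floor. Compound 2 sits at the limit of > 54300 nM in this assay, at which 1 of the 3 values shown sits. The difference between the core of compound 1 and the core of compound 2 is not broken down here.

Compound 4, `CC(C)(C)n1cc(C(=O)O)c(=O)c2cc([N+](=O)[O-])c(N3CCN(C(=O)C4COc5ccccc5O4)CC3)nc21`, has not been measured in this assay. It differs from compound 2 by tert-butyl in place of 4-fluorophenyl on an aromatic nitrogen, which is the same change as that from compound 1 to compound 3, at the same place. Since compound 2 already stands at the limit of > 54300 nM in this assay, at which 1 of the 3 values shown sits, and compound 3 at the limit of > 108000 nM in this assay, at which 1 of the 3 values shown sits, compound 4 is expected to remain weak, and the step from compound 2 to compound 4 is estimated as a step that the limit leaves unreadable from compound 2 to compound 4. For compound 4 the estimate in this assay is 100000 nM, with a range from 50000 nM to 220000 nM, and a reported limit rather than a number is considered the more likely outcome.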

Compound 4, half-maximal inhibitory concentration: 116000 nM
The estimate for compound 4 lay 1.2-fold (0.06 log units) below the measured number; measured number inside the range.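

Going by these compounds, no new step can be read from the result for compound 4, as the comparison with compound 2 in this assay rests on a limit, not a number, and its size stays unknown. That limit belongs to compound 2: the limit of > 54300 nM in this assay, at which 1 of the 4 values shown sits.

The compounds shown leave open how large the effect of tert-butyl in place of 4-fluorophenyl on an aromatic nitrogen is in this assay, in either pair that carries this change.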